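The source may report more compounds than this note shows. Statements on the series, on what has been measured and on what is new or still open speak of the compounds shown alone.

In an ADME assay on RD cells (Homo sapiens) for cytotoxicity, read by neutral red uptake, with a stated time of 3 days (a higher number here means that more compound is tolerated, a lower number that less compound is tolerated), compound 1 `CN(C)c1ccc(NC(=O)c2cc(-c3ccccc3)nc3ccccc23)cc1` reads > 350000 nM, which is a limit of the assay and not a number. Compound 2 `CCN(CC)CCCNC(=O)c1cc(-c2ccccc2)nc2ccccc12` gives 45400 nM, the lowest number of the three compounds measured, while compound 3 `CC(C)Oc1cc(C(=O)NC2CCN(C)CC2)c2ccccc2n1` stands higher at 101000 nM. The next compound, compound 4 `NNC(=O)c1cc(-c2ccccc2)nc2ccccc12`, has not yet been measured. It departs from compound 2 by one change, amino in place of 3-(diethylamino)propyl on an amide-type nitrogen.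

For the measured compounds named here, one measured step bears on this change: an at least 7.7-fold lower number from compound 1 to compound 2 (0.88 log units; beyond the scatter), in which 3-(diethylamino)propyl took the place of 4-(dimethylamino)phenyl at that same kind of nitrogen. As far as these compounds go, the size of that step stays open on one side because of the limit of > 350000 nM in this assay, at which 1 of the 3 values shown sits. Since compound 4 loses the same 3-(diethylamino)propyl group, a move back toward more compound being tolerated seems likely, though the group entering is a different one and a single step is thin support. The expected change in this assay is therefore a higher number, estimated as a 2.6-fold higher number from compound 2 to compound 4 (0.42 log units; beyond the scatter). For compound 4 the estimated value is 120000 nM, with an expected range from 45000 nM to 320000 nM.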

Compound 4, half-maximal cytotoxic concentration: > 300000 nM
Compound 4 gave a limit, no number; the forecaster's own chance of this, stated with the estimate: 25%; at least 2.5-fold (0.39 log units) between middle value and limit.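

In this assay, for the compounds shown here, the earlier compounds offered only one step at this amide-type nitrogen, the one that brought in 3-(diethylamino)propyl, and the opposite replacement with a second, different group now points the same way: an at least 6.6-fold higher number from compound 2 to compound 4 (0.82 log units; beyond the scatter). Amino and 4-(dimethylamino)phenyl have little in common as groups, yet compound 1 and compound 4 both end up on the same side of compound 2, so among these three compounds the lower number goes with 3-(diethylamino)propyl and not with one particular replacement for it. The size of the new step stays open on one side because compound 4 gives a limit and not a number: the limit of > 300000 nM in this assay, at which 1 of the 4 values shown sits.

Between compound 1 and compound 4 no step can be read, as each value is a limit, so the amino and 4-(dimethylamino)phenyl groups cannot be placed in order. The compounds shown also leave open whether the lower number depends on the diethylamino end of the chain or on the propyl chain itself, a question that a plain propyl chain without the amine, or a longer chain carrying the same amine, at this nitrogen would address.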